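The source may hold more compounds than are shown below. What is called first, only, known or untested is meant among the compounds shown, and "the series" means these compounds.

Of the compounds shown here, three share one core and have been measured. Compound 1 `CC(=O)c1cc(CC2CO2)c(OCCCCC#N)cc1O` gives 24% in an assay on isolated protein for binding affinity to leukotriene B4 receptor 1 (Homo sapiens), tested at 1 uM; a lower number here means less inhibition, a higher number more inhibition at the concentration tested (going by the name of the read-out). Compound 2 `C=CCc1cc(C(C)=O)c(O)cc1OCCCCC#N` gives 57% in this assay, a step of a number 33 percentage points higher from compound 1 to compound 2 (beyond the scatter). Compound 3 `CCc1cc(C(C)=O)c(O)cc1OCCCC(C)(C)c1nnn[nH]1` gives 76% in this assay and stands highest of the three, beyond the scatter above both compound 2 and compound 1. Compound 4 `CCc1cc(C(C)=O)c(O)cc1OCCCCCCc1nnn[nH]1` differs from compound 3 only in its tail: 3-(1H-tetrazol-5-yl)propyl in place of 1-(1H-tetrazol-5-yl)-1-methylethyl on a saturated chain carbon, three bonds along the chain from an oxygen on an aromatic ring. Among the compounds with values here, no measured step touches this tail; the single recorded step, a number 33 percentage points higher from compound 1 to compound 2 (beyond the scatter), alters a different group on the ring and does not bear on it. With nothing to lean on, only a small step is expected, a number 11 percentage points lower from compound 3 to compound 4 (beyond the scatter), in an uncertain direction. Compound 4 is expected to give 65% in this assay, within 38% to 88%.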

Compound 4, a percentage reported as inhibition, at one concentration (the size of the read-out at that concentration, not a potency): 60%
Compound 4: the middle estimate sits 5 percentage points above what was measured, and the stated range covers the measured number.
By their numbers in this assay, from the lowest: compound 1; then compounds 2 and 4 (each within the scatter of the next); then compound 3.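

In this assay, the tail at this position proves to matter even with the atoms unchanged: replacing 1-(1H-tetrazol-5-yl)-1-methylethyl with 3-(1H-tetrazol-5-yl)propyl gives a number 16 percentage points lower from compound 3 to compound 4 (beyond the scatter). Within the data shown here, how the same atoms are joined in this tail therefore shows in the read-out, a point the earlier compounds could not make. Nothing available explains the difference.

The compounds shown leave open whether a carboxylic acid in place of the tetrazole would keep the inhibition on either tail. They also leave open how a longer chain would fare.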